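Amide nitrogen substituent and mouse microsomal clearance

This account rests on a few compounds, and the source may have more. Where it says the series, first, only, none or still open, it means among the compounds named here.

Measured compounds:
compound 1 `COc1ccc(NC(=O)[C@H]2CN(C)C[C@@H]2c2ccc(/C=C/C(=O)Nc3ccccc3N)cc2)cc1`: 54 mL/min/kg
compound 2 `CN1C[C@H](C(=O)Nc2ccc(C#N)cc2)[C@@H](c2ccc(/C=C/C(=O)Nc3ccccc3N)cc2)C1`: 35 mL/min/kg
compound 3 `CC(C)NC(=O)[C@H]1CN(C)C[C@@H]1c1ccc(/C=C/C(=O)Nc2ccccc2N)cc1`: 12 mL/min/kg

All three values come from an in vitro ADME assay on microsomes from liver (Mus musculus) for pharmacokinetics, read by LC-MS, with a stated time of 10 min, tested at 1 uM; on this read-out lower numbers stand for slow clearance and higher numbers for fast clearance. Compound 2 stands second highest of the three; its nearest neighbour is compound 1, the gap a 1.5-fold lower number from compound 1 to compound 2 (0.19 log units; within the scatter) lying within the scatter, and its furthest is compound 3, with a 2.9-fold lower number from compound 2 to compound 3 (0.46 log units; beyond the scatter).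

Compound 4 `CN1C[C@H](C(=O)NC2CCCC2)[C@@H](c2ccc(/C=C/C(=O)Nc3ccccc3N)cc2)C1` differs from compound 2 by cyclopentyl in place of 4-cyanophenyl on an amide-type nitrogen. Within the data shown here, the steps that bear on this are the two in which an isopropyl replaces a six-membered aromatic ring on the same amide-type nitrogen: a 2.9-fold lower number from compound 2 to compound 3 (0.46 log units; beyond the scatter) and a 4.5-fold lower number from compound 1 to compound 3 (0.65 log units; beyond the scatter), both modest, both beyond the scatter, both toward slower clearance. Cyclopentyl is not isopropyl, and no measured compound shows how a five-membered non-aromatic ring of carbon only behaves at this place, so the size of the step is uncertain. A step toward slower clearance, beyond the scatter, is nonetheless expected, a 1.9-fold lower number from compound 2 to compound 4 (0.29 log units; within the scatter). Compound 4 is therefore estimated at 18 mL/min/kg, with a range from 9 mL/min/kg to 36 mL/min/kg.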

Compound 4, clearance: 61 mL/min/kg
Compound 4: the middle estimate sits 3.4-fold (0.53 log units) below what was measured, and the stated range ends below it.
By their numbers in this assay, from the lowest: compound 3; then compounds 2, 1 and 4 (each within the scatter of the next).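

In this assay, taking out the aromatic ring does not by itself give a low number: cyclopentyl and 4-cyanophenyl on the amide-type nitrogen read alike (a 1.7-fold higher number from compound 2 to compound 4 (0.24 log units; within the scatter)), as do cyclopentyl and 4-methoxyphenyl (a 1.1-fold higher number from compound 1 to compound 4 (0.05 log units; within the scatter)). The split between isopropyl and the two aromatic rings therefore does not hold as a split between aromatic and non-aromatic groups, and compound 4 goes against it. Among the four compounds only compound 3 stands apart, and exchanging one non-aromatic carbon group for another is enough to open a gap beyond the scatter (a 5.1-fold higher number from compound 3 to compound 4 (0.71 log units; beyond the scatter)).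

As far as these compounds go, whether the low number is confined to isopropyl or extends to cyclopropyl, cyclobutyl, tert-butyl or a longer chain such as n-butyl remains open. Nothing available accounts for the gap between compound 3 and compound 4.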